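A Chloro Gives Way to a Hydroxy

The compounds below may be only part of what the source reports. "The series", "measured", "known", "first", "only" and "open" are said of these compounds alone.

Compound 1 `COc1cccc(/C=C2\CCC/C(=C\c3cccc(O)c3)C2=O)c1OC`: 19300 nM
Compound 2 `COc1cccc(/C=C2\CCC/C(=C\c3ccc(O)c(Cl)c3)C2=O)c1OC`: 39500 nM

In an ADME assay on NHDF cells (Homo sapiens) for cytotoxicity, read by MTT assay, with a stated time of 72 h (on this read-out lower numbers stand for stronger inhibition and higher numbers for weaker inhibition), compound 2 stands highest of the two, at 39500 nM on this scale, making it the weaker inhibitor of the pair. The next compound, compound 3 `COc1cccc(/C=C2\CCC/C(=C\c3ccc(O)c(O)c3)C2=O)c1OC`, keeps the shared core and alters one group: hydroxy in place of chloro on an aromatic carbon. This is hydroxy in place of chloro on an aromatic carbon, ortho to a hydroxy group, so 3-chloro-4-hydroxyphenyl becomes 3,4-dihydroxyphenyl.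

Among the compounds with values here, only one measured step bears on this change: a 2.0-fold higher number from compound 1 to compound 2 (0.31 log units; beyond the scatter). It is modest and brought in the 3-chloro-4-hydroxyphenyl group in place of 3-hydroxyphenyl, so it is a different swap on the same part of the molecule and only a rough guide. Compound 1 also lacks the chloro and reads 19300 nM here, so a modest move towards a lower number is expected in this assay, though its size is uncertain. The expected change is a 2.0-fold lower number from compound 2 to compound 3 (0.30 log units; within the scatter) in this estimate. For compound 3 the estimated value is 20000 nM, with an expected range of 8000 nM to 45000 nM in this assay.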

Compound 3, half-maximal inhibitory concentration: 17900 nM
For compound 3 the middle estimate is 1.1-fold (0.05 log units) above the measured one; measured number inside the range.
By their numbers in this assay, from the lowest: compounds 3 and 1 (each within the scatter of the next); then compound 2.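

In this assay, hydroxy in place of chloro on this aromatic carbon gives a 2.2-fold lower number from compound 2 to compound 3 (0.34 log units; beyond the scatter), a modest step, but it shows that the two groups can be told apart at this position. The other new step gives a 1.1-fold lower number from compound 1 to compound 3 (0.03 log units; within the scatter), so compound 1 and compound 3 read alike, and among these three compounds only compound 2, with its 3-chloro-4-hydroxyphenyl group, stands apart from the other two. No measurement given here explains why chloro and hydroxy differ in this way.

The compounds shown leave open how other groups on this aromatic carbon would read, such as fluoro, methoxy, an amine or a carboxylic acid, and so whether the higher number belongs to chloro alone or would also appear with other replacements for hydroxy. Within the data shown here, with only one chloro compound in view, they also leave open whether the same step would appear if the rest of the molecule were different.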